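A few compounds are considered here, and "the series" means these few. Any claim that something is new, unique, unknown or untested is made for them only; others in the source may bear on it.

Compound 2 `Cc1cc(-c2ccccc2)cn2c(CSCCc3ccccc3)cnc12` gives 20 ug/mL in an ADME assay on HEL cells (Homo sapiens) for cytotoxicity, with a stated time of 3 days; on this read-out lower numbers stand for higher toxicity in this test and higher numbers for lower toxicity in this test. Compound 1 `COc1cccc(-c2cc(C)c3ncc(CSCCc4ccccc4)n3c2)c1` gives 20 ug/mL, and no change at the digits printed from compound 1 to compound 2 (within the scatter). Compound 3 `c1ccc(CCSCc2cnc3ccc(-c4ccccc4)cn23)cc1` gives 4 ug/mL, so a 5.0-fold lower number from compound 2 to compound 3 (0.70 log units; beyond the scatter); compound 2 thus sits level with compound 1 at the highest numbers of the three. Compound 4 `Cc1cc(Br)cn2c(CSCCc3ccccc3)cnc12` differs from compound 2 by bromo in place of phenyl on an aromatic carbon. Neither measured step involves this kind of exchange: removing methoxy left the number unchanged, removing methyl lowered it modestly, and the series gives no direct guide for bromo replacing phenyl. Compound 4 is therefore expected to stay near compound 2, with a step of about no change at the digits printed from compound 2 to compound 4 (within the scatter) and a wide range. Compound 4 is estimated at 20 ug/mL, between 5 ug/mL and 80 ug/mL.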

Compound 4, minimum cytotoxic concentration: >= 2 ug/mL
Compound 4: only a limit was reported; the forecaster's own chance of this, stated with the estimate: 20%; the middle value is on the limit's open side.
By their numbers in this assay, from the lowest: compound 3; then compounds 1 and 2 (each within the scatter of the next).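

In this assay, compound 4 gives only a limit, >= 2 ug/mL, so its steps from compound 1 and compound 2 cannot be read. Going by these compounds, whether bromo in place of phenyl shifts the number at all remains open.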